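Enlarging the amide substituent of compound 2

The source may report more compounds than this note shows. Statements on the series, on what has been measured and on what is new or still open speak of the compounds shown alone.

Compound 1 `Cn1ccc2ccc(-c3cc(Nc4ccccc4S(=O)(=O)Nc4cncnc4)cc4nccnc34)cc21`: 1690 nM
Compound 2 `CNC(=O)c1ccncc1Nc1cc(-c2ccc3ccn(C)c3c2)c2nccnc2c1`: 83 nM

In an assay for inhibition of 6-phosphofructo-2-kinase/fructose-2,6-bisphosphatase 3 (Homo sapiens), read by ADP-Glo, with a stated time of 2 h (on this read-out lower numbers stand for stronger inhibition and higher numbers for weaker inhibition), compound 2 gives 83 nM, the lower of the two numbers; compound 1 gives 1690 nM, a gap beyond the scatter. Compound 3 `CN1CCC(NC(=O)c2ccncc2Nc2cc(-c3ccc4ccn(C)c4c3)c3nccnc3c2)CC1=O` carries 1-methyl-2-oxopiperidin-4-yl in place of methyl on an amide-type nitrogen. Among the measured compounds shown here, no measured pair shows this change, so the expectation rests on compound 2 alone. A modest weakening, or none beyond the scatter, is expected, and the step from compound 2 to compound 3 in this assay is estimated at a 1.4-fold higher number from compound 2 to compound 3 (0.16 log units; within the scatter). Compound 3 is expected to give 120 nM, within 40 nM to 400 nM.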

Compound 3, half-maximal inhibitory concentration: 41 nM
Estimate against measurement, compound 3: 2.9-fold (0.47 log units) above; the measured number falls inside the stated range.
By their numbers in this assay, from the lowest: compound 3; then compound 2; then compound 1.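

In this assay, replacing methyl on the amide-type nitrogen with 1-methyl-2-oxopiperidin-4-yl gives a 2.0-fold lower number from compound 2 to compound 3 (0.31 log units; beyond the scatter), a modest gain. This position, seen until now only with methyl in compound 2, therefore accepts a far larger substituent containing a six-membered non-aromatic ring without any loss. Nothing available explains the gain. The compounds shown do not reveal which part of the new group matters, the ring, its carbonyl or its methyl. A plain piperidin-4-yl or an open chain ending in an amine could separate these contributions.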